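The source may hold more compounds than are shown below. What is called first, only, known or untested is meant among the compounds shown, and "the series" means these compounds.

Among the measured compounds shown here, in a physicochemical assay for solubility (on this read-out lower numbers stand for lower solubility and higher numbers for higher solubility), compound 1 `CN(C)c1ccc(C(=O)N2CCC(NS(=O)(=O)c3cc(S(=O)(=O)c4ccccc4)ccc3C(F)(F)F)CC2)cc1` gives 50000 nM and compound 2 `CC(C)(C)OC(=O)N1CCC[C@@H]1C(=O)N1CCC(NS(=O)(=O)c2cc(S(=O)(=O)c3ccccc3)ccc2C(F)(F)F)CC1` gives 25000 nM, so compound 2 stands within the usual scatter of the only other measured compound. Compound 3 `CC(C)(C)OC(=O)N1CC[C@@H](C(=O)N2CCC(NS(=O)(=O)c3cc(S(=O)(=O)c4ccccc4)ccc3C(F)(F)F)CC2)C1` differs from compound 2 by one change on the same carbonyl carbon, where 1-(tert-butoxycarbonyl)pyrrolidin-3-yl replaces 1-(tert-butoxycarbonyl)pyrrolidin-2-yl: 1-(tert-butoxycarbonyl)pyrrolidin-3-yl in place of 1-(tert-butoxycarbonyl)pyrrolidin-2-yl on a carbonyl carbon. For the measured compounds named here, the only measured step at that carbon is a 2.0-fold lower number from compound 1 to compound 2 (0.30 log units; within the scatter), and it stayed within the scatter. No step beyond the scatter is therefore expected in this assay. The estimated step is no change at the digits printed from compound 2 to compound 3 (within the scatter). The expected value for compound 3 is 25000 nM, within an estimated range of 12000 nM to 50000 nM.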

Compound 3, solubility: 12500 nM
Compound 3: middle estimate off by 2.0-fold (0.30 log units), on the high side; measured number inside the range.
By their numbers in this assay, from the lowest: compounds 3, 2 and 1 (each within the scatter of the next, the first and the last beyond it).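

In this assay, exchanging 1-(tert-butoxycarbonyl)pyrrolidin-2-yl for 1-(tert-butoxycarbonyl)pyrrolidin-3-yl on the carbonyl carbon joins the same atoms differently and gives a 2.0-fold lower number from compound 2 to compound 3 (0.30 log units; within the scatter) and so does not separate the two compounds. Among the compounds shown here, exchanging 4-(dimethylamino)phenyl for 1-(tert-butoxycarbonyl)pyrrolidin-3-yl at this carbon gives a 4.0-fold lower number from compound 1 to compound 3 (0.60 log units; beyond the scatter) and is the first step here to pass the scatter, though only modestly. The compounds shown leave open how a free amine in place of the tert-butoxycarbonyl group, or a carboxylic acid on the pyrrolidine ring, would read out. Nothing available explains these differences.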